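This account rests on a few compounds, and the source may have more. Where it says the series, first, only, none or still open, it means among the compounds named here.

Compound 1 `O=S(=O)(/C=C/c1ccc(O)c(O)c1)CC1CC1`: 10500 nM
Compound 2 `O=S(=O)(/C=C/c1ccc(O)c(O)c1)CC1CCCN1`: 13800 nM
Compound 3 `CCCCCS(=O)(=O)/C=C/c1ccc(O)c(O)c1`: 8100 nM

All three were measured in a functional assay, read by fluorescence and spectrophotometry, with a stated time of 1 h; a higher number here means that more compound is needed for the effect, a lower number that less compound is needed. The number for compound 3 is not separated from those of the other two: a 1.3-fold lower number from compound 1 to compound 3 (0.11 log units; within the scatter) and a 1.7-fold lower number from compound 2 to compound 3 (0.23 log units; within the scatter) both fall within the scatter, as does a 1.3-fold higher number from compound 1 to compound 2 (0.12 log units; within the scatter), so the three stand together. Compound 4 `CCCCCCCCS(=O)(=O)/C=C/c1ccc(O)c(O)c1` differs from compound 3 by propyl in place of hydrogen on a saturated chain carbon, five bonds along the chain from a sulfonyl sulfur. Within the data shown here, no measured step lengthens the chain itself; the nearest comparisons are the exchanges of cyclopropyl or pyrrolidin-2-yl for butyl, which moved nothing beyond the scatter. The expected step is therefore a 1.1-fold lower number from compound 3 to compound 4 (0.03 log units; within the scatter), nothing beyond the scatter. Compound 4 is estimated at 7500 nM, within 3500 nM to 16000 nM.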

Compound 4, half-maximal effective concentration: 6400 nM
Compound 4: middle estimate off by 1.2-fold (0.07 log units), on the high side; the range from low to high includes it.
By their numbers in this assay, from the lowest: compounds 4, 3, 1 and 2 (each within the scatter of the next, the first and the last beyond it).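

Propyl in place of hydrogen at this position, five bonds along the chain from the sulfonyl sulfur, stays within the scatter in this assay (a 1.3-fold lower number from compound 3 to compound 4 (0.10 log units; within the scatter)). Heptyl in place of cyclopropyl also stays within it (a 1.6-fold lower number from compound 1 to compound 4 (0.22 log units; within the scatter)), whereas heptyl in place of pyrrolidin-2-yl gives the only step in the series that clears the scatter, and only modestly (a 2.2-fold lower number from compound 2 to compound 4 (0.33 log units; beyond the scatter)). Nothing available gives a reason for that step. As far as these compounds go, what a longer chain, or a carboxylic acid or amine in place of heptyl, would do to the number remains open.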